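A few compounds are considered here, and "the series" means these few. Any claim that something is new, unique, unknown or untested is made for them only; others in the source may bear on it.

Measured so far in a functional assay on SNB-75 cells (Homo sapiens) for inhibition, read by sulforhodamine B assay, with a stated time of 48 h, tested at 100 uM; on this read-out lower numbers stand for a stronger effect and higher numbers for a weaker effect at the one concentration tested: compound 1 `COc1cc(Cl)cc(-c2nn(-c3cccc(NC(=O)Nc4ccc(Cl)c(C(F)(F)F)c4)c3)cc2-c2ccncc2)c1` gives -38%; compound 2 `COc1cc(Cl)cc(-c2nn(-c3cccc(NC(=O)Nc4cc(C(F)(F)F)cc(C(F)(F)F)c4)c3)cc2-c2ccncc2)c1` gives -58%; compound 3 `COc1cc(Cl)cc(-c2nn(-c3cccc(NC(=O)Nc4ccc(Cl)c(Cl)c4)c3)cc2-c2ccncc2)c1` gives -3%.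

Compound 3 stands highest of the three numbers in this assay; compound 1 lies below it beyond the scatter, and compound 2 lies further below still. Compound 4 `COc1cc(Cl)cc(-c2nn(-c3cccc(NC(=O)Nc4cccc(C(F)(F)F)c4)c3)cc2-c2ccncc2)c1` differs from compound 3 by 3-(trifluoromethyl)phenyl in place of 3,4-dichlorophenyl on an amide-type nitrogen. For the measured compounds named here, one measured step bears on this change: a number 35 percentage points higher from compound 1 to compound 3 (beyond the scatter), where a trifluoromethyl gave way to chloro and the number rose sharply. Compound 4 brings a trifluoromethyl back in while also giving up a chloro, for which no step is shown. Compound 4 is therefore expected to move downward in this assay, by a number 22 percentage points lower from compound 3 to compound 4 (beyond the scatter). The estimated value of compound 4 is -25%, between -55% and 5%.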

Compound 4, a percentage reported as activity, at one concentration (the size of the read-out at that concentration, not a potency): -17%
Beside the measured number, compound 4's estimate is 8 percentage points below it; measured number inside the range.
By their numbers in this assay, from the lowest: compound 2; then compound 1; then compound 4; then compound 3.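

In this assay, the ring on the amide-type nitrogen responds to each group taken from it: with hydrogen in place of trifluoromethyl the result is a number 41 percentage points higher from compound 2 to compound 4 (beyond the scatter) and with hydrogen in place of chloro it is a number 21 percentage points higher from compound 1 to compound 4 (beyond the scatter), so in both pairs the second group goes with the lower number. Even so, 3-(trifluoromethyl)phenyl in place of 3,4-dichlorophenyl still gives a number 14 percentage points lower from compound 3 to compound 4 (beyond the scatter), so a single trifluoromethyl on this ring outdoes two chloro groups here. Nothing measured here explains these shifts.

On these data alone, how an amine or a carboxylic acid on this ring would read remains open.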